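A few compounds are considered here, and "the series" means these few. Any claim that something is new, unique, unknown or untested is made for them only; others in the source may bear on it.

Compound 1, whose structure is `Cc1ccc(S(=O)(=O)NC(C)C)cc1C#Cc1cc(Cl)ccc1OCC(=O)O`, was tested in a functional assay on cells for antagonist activity at prostaglandin D2 receptor 2 (Homo sapiens), read by flow cytometry, with a stated time of 10 min (on this read-out lower numbers stand for stronger inhibition and higher numbers for weaker inhibition), and gave 250 nM. Among the three compounds measured here, compound 1 sits with the highest number: compound 2 `CCCS(=O)(=O)c1ccc(F)c(C#Cc2cc(Cl)ccc2OCC(=O)O)c1` gives 23 nM, and compound 3 `CS(=O)(=O)c1ccc(Cl)c(C#Cc2cc(Cl)ccc2OCC(=O)O)c1` gives 26 nM, so both of those stand well beyond the usual scatter from compound 1. The next compound, compound 4 `Cc1ccc(S(=O)(=O)N2CCCCC2C)cc1C#Cc1cc(Cl)ccc1OCC(=O)O`, differs from compound 1 in a single place: 2-methylpiperidin-1-yl in place of isopropylamino on a sulfonyl sulfur. The sulfonyl sulfur keeps its aromatic carbon neighbour, but the nitrogen it carries is now part of a ring and no longer bears a hydrogen. Within the data shown here, with no measured pair showing this exact change, the step expected for compound 4 is a 1.7-fold lower number from compound 1 to compound 4 (0.22 log units; within the scatter), a small shift and not clearly beyond the scatter. Compound 4 is therefore expected to give about 150 nM, within 40 nM to 600 nM.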

Compound 4, half-maximal inhibitory concentration: 310 nM
The estimate for compound 4 lay 2.1-fold (0.32 log units) below the measured number; low and high end bracket the measured number.
By their numbers in this assay, from the lowest: compounds 2 and 3 (each within the scatter of the next); then compounds 1 and 4 (each within the scatter of the next).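

On the sulfonyl sulfur, isopropylamino can give way to 2-methylpiperidin-1-yl, with a 1.2-fold higher number from compound 1 to compound 4 (0.09 log units; within the scatter) in this assay. In this one pair, the group's hydrogen-bond donor is lost and a six-membered ring enters, yet the two numbers stay within the scatter of each other. Nothing available explains this result. Going by these compounds, it remains open what a morpholine ring or a plain piperidine without the methyl would give on the same sulfur, and whether a smaller amine such as dimethylamino would match these two compounds.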